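Ethoxycarbonyl in place of 4-butylcyclohexyl: expected shift in tolerance

This account rests on a few compounds, and the source may have more. Where it says the series, first, only, none or still open, it means among the compounds named here.

In an ADME assay on BHK cells (Mesocricetus auratus) for cytotoxicity, read by MTT assay, with a stated time of 96 h (a lower number here means that less compound is tolerated, a higher number that more compound is tolerated), compound 1 (`CCCC[C@H]1CC[C@H](c2ccc(NC(=S)Nc3cccc(C(F)(F)F)c3)cc2)CC1`) gives 9500 nM and stands lowest of the two numbers available. Compound 2 (`Fc1ccccc1NC(=S)Nc1cccc(C(F)(F)F)c1`) gives 54000 nM as the higher number, and the gap between them lies beyond the usual scatter. Among the measured compounds shown here, no step at a single site links these two, so neither value can be tied to one group. Compound 3 (`CCOC(=O)c1ccc(NC(=S)Nc2cccc(C(F)(F)F)c2)cc1`) carries ethoxycarbonyl in place of 4-butylcyclohexyl on an aromatic carbon. For the measured compounds named here, compound 2 also lacks 4-butylcyclohexyl and gives 54000 nM as the only guide, so a higher number is expected for this change. In this assay a rise beyond the scatter is expected (a 3.2-fold higher number from compound 1 to compound 3 (0.50 log units; beyond the scatter)) with moderate confidence. The estimate for compound 3 is 30000 nM with an expected range from 10000 nM to 90000 nM (both ends estimated).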

Compound 3, half-maximal cytotoxic concentration: 50000 nM
For compound 3 the middle estimate is 1.7-fold (0.22 log units) below the measured one, within the range that was stated.
By their numbers in this assay, from the lowest: compound 1; then compounds 3 and 2 (each within the scatter of the next).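

In this assay, among the compounds shown here, ethoxycarbonyl in place of 4-butylcyclohexyl gives a 5.3-fold higher number from compound 1 to compound 3 (0.72 log units; beyond the scatter), the only step so far that changes a single site. It shows that the group on this aromatic carbon, para to a large group, can by itself shift the tolerated concentration beyond the scatter, with the rest of the structure held constant. Nothing available explains the size or direction of this step.

The non-aromatic ring and the butyl chain of 4-butylcyclohexyl leave together in this one change, so the step does not separate their contributions. Also open, going by these compounds, is how a plain butyl chain, a cyclohexyl ring without the chain, a carboxylic acid or an amine at this position would read in this assay.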